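The source may hold more compounds than are shown below. What is called first, only, known or untested is meant among the compounds shown, and "the series" means these compounds.

Three amides sharing one core have been measured in an in vitro functional assay on HEK293-A cells for antagonist activity at metabotropic glutamate receptor 5 (Rattus norvegicus), read by calcium flux; on this read-out lower numbers stand for stronger inhibition and higher numbers for weaker inhibition. Compound 1 `N#Cc1cc(F)cc(C(=O)Nc2ccccn2)c1` gives 3010 nM in this assay. Compound 2 `N#Cc1cc(F)cc(C(=O)Nc2cccc(F)c2)c1` gives 2160 nM in this assay. For compound 3 `Cc1ccccc1NC(=O)c1cc(F)cc(C#N)c1` the read-out in this assay is only a limit, > 30000 nM, at which one of the three values sits (the limit of > 30000 nM in this assay, at which 1 of the 3 values shown sits). Among the numbers that are actual numbers, compound 2 and compound 1 lie within the usual scatter of each other, so no order between them can be claimed; the third result is a limit rather than a number.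

The compound not yet measured is compound 4 `N#Cc1cc(F)cc(C(=O)Nc2cccc(C(F)(F)F)c2)c1`. It differs from compound 2 in one place: trifluoromethyl in place of fluoro on an aromatic carbon. Among the compounds with values here, no step between two measured compounds covers this exchange, so the expectation rests on the value of compound 2 alone. The change expected in this assay is a 1.4-fold lower number from compound 2 to compound 4 (0.16 log units; within the scatter), small enough to fall within or near the scatter, with no confident direction. Compound 4 is therefore estimated at 1500 nM in this assay, with a range from 500 nM to 5000 nM.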

Compound 4, half-maximal inhibitory concentration: 543 nM
Compound 4: the middle estimate sits 2.8-fold (0.44 log units) above what was measured, and the stated range covers the measured number.
By their numbers in this assay, from the lowest: compound 4; then compounds 2 and 1 (each within the scatter of the next). At a limit, above all of these: compound 3.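

In this assay, within the data shown here, trifluoromethyl in place of fluoro on an aromatic carbon, meta to a large group, gives the first step in this set that joins two measured compounds differing in one place: a 4.0-fold lower number from compound 2 to compound 4 (0.60 log units; beyond the scatter) for this exchange. Until now, the only numbers in the set lay within the scatter of each other, so nothing had shown that the read-out could separate compounds at all, whereas this position now shows a change beyond the scatter, with a group of 4 heavy atoms entering where 1 left and compound 4 reaching 543 nM as the number. Nothing measured here accounts for the size or the direction of this step, which so far rests on a single pair.

Open, from the compounds shown here alone, is whether an amine, a methoxy group or a longer chain on this same aromatic carbon would hold the number of compound 4 or lose it. Also open, going by these compounds, is whether the same exchange gives a step of like size when made on another compound sharing this core, such as one built on the amide of compound 1.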